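Trading the 2-chlorophenyl of Compound 3 for Cyclopropyl

The source may report more compounds than this note shows. Statements on the series, on what has been measured and on what is new or still open speak of the compounds shown alone.

The three measured compounds share one core and differ only in the group on the nitrogen on an aromatic ring. Compound 1 `O=C(CCCCCCn1cc(Nc2ncc(Cl)c(Nc3ccc(F)cc3)n2)cn1)NO` gives 220 nM in a functional assay on MOLT-4 cells (Homo sapiens) for antiproliferative activity, read by MTT assay, with a stated time of 48 h; on this read-out higher numbers stand for weaker inhibition and lower numbers for stronger inhibition. Compound 2 `O=C(CCCCCCn1cc(Nc2ncc(Cl)c(Nc3ccccc3)n2)cn1)NO` gives 160 nM, and a 1.4-fold lower number from compound 1 to compound 2 (0.14 log units; within the scatter). Compound 3 `O=C(CCCCCCn1cc(Nc2ncc(Cl)c(Nc3ccccc3Cl)n2)cn1)NO` gives 510 nM, the highest of the three numbers: a 2.3-fold higher number from compound 1 to compound 3 (0.37 log units; beyond the scatter), and a 3.2-fold higher number from compound 2 to compound 3 (0.50 log units; beyond the scatter).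

Compound 4 `O=C(CCCCCCn1cc(Nc2ncc(Cl)c(NC3CC3)n2)cn1)NO` carries the change (cyclopropyl in place of 2-chlorophenyl on a nitrogen on an aromatic ring). Among the compounds with values here, no measured step bears directly on this: every step so far swaps one substituent on a phenyl ring for another, whereas here the whole ring leaves and a three-membered non-aromatic ring of carbon only enters in its place. What the three values do show is that varying the aryl group moves the number only over a modest span, with compound 3 at the weak end of it.

Without a comparable step, the expectation for compound 4 in this assay is a number near that of compound 3, with a wide range on either side; the step of a 1.3-fold lower number from compound 3 to compound 4 (0.11 log units; within the scatter) is estimated to be small. Compound 4 is therefore expected to give about 400 nM, somewhere between 120 nM and 1500 nM.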

Compound 4, half-maximal inhibitory concentration: 150 nM
Beside the measured number, compound 4's estimate is 2.7-fold (0.43 log units) above it, and the stated range covers the measured number.
By their numbers in this assay, from the lowest: compounds 4, 2 and 1 (each within the scatter of the next); then compound 3.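

In this assay the aromatic ring on this nitrogen proves dispensable: cyclopropyl in place of phenyl gives a 1.1-fold lower number from compound 2 to compound 4 (0.03 log units; within the scatter) and stays level with the parent, and cyclopropyl in place of 4-fluorophenyl gives a 1.5-fold lower number from compound 1 to compound 4 (0.17 log units; within the scatter) with the same outcome. Cyclopropyl in place of 2-chlorophenyl gives a 3.4-fold lower number from compound 3 to compound 4 (0.53 log units; beyond the scatter) and is the only one of the three new steps beyond the scatter, so a group of 3 heavy atoms and no aromatic ring does as well here as the unsubstituted phenyl, and among these four compounds only compound 3 stands apart, as the weakest. Nothing shown here explains why compound 3 differs from the other three or why the ring can leave without loss.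

The compounds shown leave open whether this tolerance extends beyond cyclopropyl, for instance to an isopropyl or cyclohexyl group on this nitrogen, or to a short chain ending in an amine. They also leave open whether the weaker number of compound 3 is tied to where its chloro sits, which a 4-chlorophenyl group on the same nitrogen would address.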